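Oxygen to Sulfur Linker Swap on a Shared Core

The source may hold more compounds than are shown below. What is called first, only, known or untested is meant among the compounds shown, and "the series" means these compounds.

Three compounds have been measured in a functional assay on NCI-H322M cells (Homo sapiens) for inhibition, read by sulforhodamine B assay, with a stated time of 48 h; a lower number here means that less compound is tolerated, a higher number that more compound is tolerated:

Compound 1 `Nc1cc(N)c2nc(-c3ccccc3)c(Oc3ccc(Cl)c(Cl)c3)nc2c1`: < 100000 nM, a limit of the assay rather than a number.
Compound 2 `COc1ccc(Sc2nc3cc(N)cc(N)c3nc2-c2ccccc2)cc1`: < 100000 nM, likewise a limit.
Compound 3 `Nc1cc(N)c2nc(-c3ccccc3)c(Oc3ccc(F)cc3)nc2c1`: 81300 nM.

Compound 3 is therefore the only one of the three with a real number in this assay; the other two sit at the limit of < 100000 nM in this assay, at which 2 of the 3 values shown sit, so no order among the three can be read.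

Compound 4 `Nc1cc(N)c2nc(-c3ccccc3)c(Sc3ccc(F)cc3)nc2c1` differs from compound 3 in one place: (4-fluorophenyl)sulfanyl in place of 4-fluorophenoxy on an aromatic carbon. The measured steps that touch this series are all unreadable: a step that the two limits leave unreadable from compound 1 to compound 2, a step that the limit leaves unreadable from compound 1 to compound 3 and a step that the limit leaves unreadable from compound 2 to compound 3 each run into a limit, so none of them shows how large a change of the linker atom or of the ring substituent can be. Among the measured compounds shown here, no measured step therefore bears directly on the oxygen-to-sulfur swap, and the plain expectation is a step in this assay no larger than the usual scatter.

On that basis compound 4 is expected to give an estimated 80000 nM, with a likely range from 30000 nM to 200000 nM. The estimated step from compound 3 to compound 4 is a 1.0-fold lower number from compound 3 to compound 4 (0.01 log units; within the scatter), which is within the scatter.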

Compound 4, concentration lethal to 50% of the cells: 70800 nM
Estimate against measurement, compound 4: 1.1-fold (0.05 log units) above; low and high end bracket the measured number.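

Among the compounds shown here, this pair gives the first readable step. In this assay, with the fluorinated ring kept the same, (4-fluorophenyl)sulfanyl in place of 4-fluorophenoxy gives a 1.1-fold lower number from compound 3 to compound 4 (0.06 log units; within the scatter). At this position, next to the ring nitrogen and ortho to a phenyl group, the oxygen and sulfur linkers therefore cannot be told apart in this assay, at least with this ring attached. The steps from compound 1 and from compound 2 to compound 4 still cannot be read, because each of those two compounds carries a limit rather than a number: the limit of < 100000 nM in this assay, at which 2 of the 4 values shown sit.

Only one pair shown differs in the linker atom alone, so it remains open whether the swap would be equally small with a 3,4-dichlorophenyl or a 4-methoxyphenyl ring. Also open, from the compounds shown here alone, is how an amine nitrogen or a methylene carbon would read as the linker at this position, and whether a longer chain there would move the number beyond the scatter.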